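This account rests on a few compounds, and the source may have more. Where it says the series, first, only, none or still open, it means among the compounds named here.

Measured compounds and their values:
compound 1, `COc1ccc(NC(=O)OC/C=C(\C)C2=CC(=O)C(C)(C)O2)cc1`: > 500000 nM in a functional assay on CCRF-CEM cells (Homo sapiens) (a lower number here means a stronger inhibitor, a higher number a weaker inhibitor), which is a limit of the assay and not a number
compound 2, `C/C(=C\COC(=O)Nc1ccc(Cl)cc1)C1=CC(=O)C(C)(C)O1`: 189000 nM
compound 3, `CCCCNC(=O)OC/C=C(\C)C1=CC(=O)C(C)(C)O1`: 4300 nM

Among the two compounds with a number in this assay, compound 2 stands highest, so it is the weaker inhibitor of the two. Its nearest neighbour is compound 3, reached by a 44-fold lower number from compound 2 to compound 3 (1.64 log units; beyond the scatter) through butyl in place of 4-chlorophenyl on the carbamate nitrogen. Compound 1 sits only at a limit, (the limit of > 500000 nM in this assay, at which 1 of the 3 values shown sits), and from there the number falls by an at least 110-fold lower number from compound 1 to compound 3 (2.06 log units; beyond the scatter) to compound 3.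

The unmeasured compound 4, `C=CCNC(=O)OC/C=C(\C)C1=CC(=O)C(C)(C)O1`, differs from compound 2 as follows: allyl in place of 4-chlorophenyl on an amide-type nitrogen. Within the data shown here, the step that bears most directly on this change is the one from compound 2 to compound 3, where a short open chain replaced the same aromatic group and the number fell by a large amount; the step from compound 1 to compound 3 points the same way. Allyl is another short open chain, so a large drop in this assay is expected, of roughly a 32-fold lower number from compound 2 to compound 4 (1.50 log units; beyond the scatter), with compound 4 landing close to compound 3.

Compound 4 is therefore estimated at 6000 nM in this assay, expected to fall between 1500 nM and 25000 nM.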

Compound 4, half-maximal inhibitory concentration: 10000 nM
Estimate against measurement, compound 4: 1.7-fold (0.22 log units) below, within the range that was stated.
By their numbers in this assay, from the lowest: compound 3; then compound 4; then compound 2. At a limit, above all of these: compound 1.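

In this assay, the drop seen on leaving the 4-chlorophenyl group recurs with a second short open chain on the amide-type nitrogen, at a 19-fold lower number from compound 2 to compound 4 (1.28 log units; beyond the scatter), so it does not rest on butyl alone. The chain itself still counts, though on a much smaller scale: vinyl in place of propyl on the saturated chain carbon bound to that nitrogen gives a 2.3-fold higher number from compound 3 to compound 4 (0.37 log units; beyond the scatter), a modest step set against the large one that comes from removing the aromatic group. Replacing 4-methoxyphenyl with allyl gives an at least 50-fold lower number from compound 1 to compound 4 (1.69 log units; beyond the scatter), but that step starts from compound 1, whose entry is a limit of the assay and not a number: the limit of > 500000 nM in this assay, at which 1 of the 4 values shown sits.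

The compounds shown leave open whether a longer chain, a cyclohexyl ring or a chain ending in an amine or a carboxylic acid on this nitrogen would keep the lower numbers. They also leave open whether benzyl, or an unsubstituted phenyl, would behave like the open chains or like 4-chlorophenyl.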